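From a Methylphenyl to a Fluorophenyl Analogue

This account rests on a few compounds, and the source may have more. Where it says the series, first, only, none or still open, it means among the compounds named here.

The measured compounds, with their values in a functional assay on HepG2 cells (Homo sapiens) for antiproliferative activity, read by MTT assay, with a stated time of 24 h; a lower number here means a stronger inhibitor, a higher number a weaker inhibitor:
Compound 1 `Cc1cccc(-n2cc(-c3ccccc3NS(=O)(=O)c3c[nH]c(=O)[nH]c3=O)nn2)c1`: 3620 nM
Compound 2 `O=c1[nH]cc(S(=O)(=O)Nc2cccc(-c3cn(-c4ccccc4)nn3)c2)c(=O)[nH]1`: 11200 nM
Compound 3 `Cc1cccc(-n2cc(-c3cccc(NS(=O)(=O)c4c[nH]c(=O)[nH]c4=O)c3)nn2)c1`: 7050 nM

Compound 3 stands second highest of the three numbers in this assay; compound 2 is its nearest neighbour and compound 1 its furthest, and both of those gaps lie within the scatter. Compound 4 `O=c1[nH]cc(S(=O)(=O)Nc2cccc(-c3cn(-c4ccccc4F)nn3)c2)c(=O)[nH]1` differs from compound 3 by 2-fluorophenyl in place of 3-methylphenyl on an aromatic nitrogen. For the measured compounds named here, only one measured step bears on this change, and only on part of it: the step of a 1.6-fold lower number from compound 2 to compound 3 (0.20 log units; within the scatter), in which a methyl was placed on the phenyl that sits on the aromatic nitrogen, stayed within the scatter. Going by the values given here, no measured compound carries a fluorine, so nothing measured bears on that part of the change. On this basis compound 4 is expected to sit near compound 3, with a 1.1-fold higher number from compound 3 to compound 4 (0.05 log units; within the scatter) expected to stay within the scatter. Compound 4 is estimated at 8000 nM, with a range from 3000 nM to 25000 nM.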

Compound 4, half-maximal inhibitory concentration: 13900 nM
For compound 4 the middle estimate is 1.7-fold (0.24 log units) below the measured one, and the stated range covers the measured number.
By their numbers in this assay, from the lowest: compounds 1, 3, 2 and 4 (each within the scatter of the next, the first and the last beyond it).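

In this assay, replacing the group on the aromatic nitrogen gave a 2.0-fold higher number from compound 3 to compound 4 (0.29 log units; within the scatter), and placing fluoro on the unsubstituted phenyl gave a 1.2-fold higher number from compound 2 to compound 4 (0.09 log units; within the scatter). Compound 4 brings the first fluorine into the set, and together with the earlier step of a 1.6-fold lower number from compound 2 to compound 3 (0.20 log units; within the scatter) it shows that neither 3-methylphenyl nor 2-fluorophenyl at this position moves the number beyond the scatter from the unsubstituted phenyl of compound 2. No available evidence accounts for these steps. The compounds shown leave open whether a different group on this phenyl, such as an amine or a carboxylic acid, or a longer chain in its place, would produce a step beyond the scatter. They also leave open how 2-fluorophenyl would read on the core of compound 1.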